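The source may report more compounds than this note shows. Statements on the series, on what has been measured and on what is new or still open speak of the compounds shown alone.

Measured in a functional assay on MGC-803 cells (Homo sapiens) for antiproliferative activity, read by MTT assay, with a stated time of 72 h; on this read-out higher numbers stand for weaker inhibition and lower numbers for stronger inhibition:
compound 1 `Cc1ccccc1-n1nc(-c2ccccc2)nc1CNc1ccc(C(=O)NO)cc1`: 12300 nM
compound 2 `Cc1ccc(-c2nc(CNc3ccc(C(=O)NO)cc3)n(-c3ccccc3)n2)cc1`: > 20000 nM (a limit of the assay, not a number)
compound 3 `O=C(NO)c1ccc(NCc2nc(-c3cccs3)nn2-c2ccc(O)cc2)cc1`: > 20000 nM (a limit of the assay, not a number)

Compound 1 is the only one of the three with a true number. Compound 4 `O=C(NO)c1ccc(NCc2nc(-c3ccccc3)nn2-c2ccccc2Cl)cc1` differs from it by chloro in place of methyl on an aromatic carbon, with chloro in place of methyl on an aromatic carbon, ortho to a large group, so 2-methylphenyl becomes 2-chlorophenyl. Going by the values given here, no measured pair covers this change, so no shift beyond the usual scatter is expected in this assay. The expected change is a 1.0-fold lower number from compound 1 to compound 4 (0.01 log units; within the scatter). Among the compounds with values here, the only numerical anchor is compound 1 at 12300 nM. A reading at the limit also remains possible for compound 4. Compound 4 is estimated at 12000 nM, with an expected range of 5000 nM to 20000 nM.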

Compound 4, half-maximal inhibitory concentration: 9630 nM
Compound 4: the middle estimate sits 1.2-fold (0.10 log units) above what was measured; the measured number falls inside the stated range.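

In this assay, the change from 2-methylphenyl to 2-chlorophenyl, on an aromatic carbon ortho to a large group, gives a 1.3-fold lower number from compound 1 to compound 4 (0.11 log units; within the scatter). Going by these compounds alone, this is the first step that can be read, and on this read-out methyl and chloro are interchangeable at this position. Compound 1 and compound 4 both give true numbers, and the other values are a limit: the limit of > 20000 nM in this assay, at which 2 of the 4 values shown sit.

Still open, on these data alone, is whether a methoxy group, an amine or a carboxylic acid at this position would also stay within the scatter. Plain hydrogen in place of chloro is equally untested among the compounds shown.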